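Sulfonamide series: naphthalen-1-yl for phenyl on the nitrogen

The source may hold more compounds than are shown below. What is called first, only, known or untested is meant among the compounds shown, and "the series" means these compounds.

Measured so far in an assay on HEK293 cells for displacement of a labelled ligand from 5-hydroxytryptamine receptor 6 (Homo sapiens), read by radioligand binding, with a stated time of 60 min, tested at 100 nM; a lower number here means less inhibition, a higher number more inhibition at the concentration tested (going by the name of the read-out):
compound 1, `O=c1sc2cc(N(S(=O)(=O)c3ccccc3)S(=O)(=O)c3ccccc3)ccc2n1CCN1CCCC1`, 20%
compound 2, `CN(c1ccccc1)S(=O)(=O)c1ccc2c(c1)sc(=O)n2CCN1CCCC1`, 10%
compound 3, `CN(c1ccccc1)S(=O)(=O)c1ccc2c(c1)sc(=O)n2CCN1CCCCC1`, 0%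

Compound 2 gives 10% in this assay. The values of compound 1 and compound 3 each differ from it by an amount within the usual scatter, so the three numbers cannot be ordered with confidence. For the measured compounds named here, the one single-point step, a number 10 percentage points lower from compound 2 to compound 3 (within the scatter), concerns the amine ring and lies within the scatter. Compound 1 differs from compound 2 in more than one place, so its value says nothing about any single change.

Compound 4, `CN(c1cccc2ccccc12)S(=O)(=O)c1ccc2c(c1)sc(=O)n2CCN1CCCC1`, differs from compound 2 as follows: naphthalen-1-yl in place of phenyl on a sulfonamide nitrogen. Going by the values given here, no measured step touches the group on the sulfonamide nitrogen, so there is nothing to set a direction or size for this change. The expectation for the step of a number 5 percentage points higher from compound 2 to compound 4 (within the scatter) is therefore no movement beyond the scatter. Compound 4 is estimated at 15% in this assay, with a range from 0% to 40%.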

Compound 4, a percentage reported as inhibition, at one concentration (the size of the read-out at that concentration, not a potency): 40%
Compound 4: the middle estimate sits 25 percentage points below what was measured; measured number inside the range.
By their numbers in this assay, from the lowest: compounds 3, 2 and 1 (each within the scatter of the next, the first and the last beyond it); then compound 4.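

In this assay naphthalen-1-yl in place of phenyl on a sulfonamide nitrogen gives a number 30 percentage points higher from compound 2 to compound 4 (beyond the scatter) and is the only single change shown that passes the scatter. The position therefore responds to the aromatic group it carries, and the change from 6 to 10 heavy atoms, all carbon, adds a second six-membered aromatic ring with no hydrogen-bond donors or acceptors on either side. No evidence is available on what lies behind this step.

Open, from the compounds shown here alone, is how naphthalen-2-yl or a benzyl group on the same nitrogen would compare with naphthalen-1-yl. Also open, going by these compounds, is whether piperidin-1-yl in place of pyrrolidin-1-yl would stay within the scatter when the sulfonamide nitrogen carries naphthalen-1-yl.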